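The compounds below may be only part of what the source reports. "The series", "measured", "known", "first", "only" and "open" are said of these compounds alone.

Working notes on an assay on isolated protein for inhibition of coagulation factor X (Oryctolagus cuniculus), tested at 1 uM; on this read-out lower numbers stand for less inhibition and higher numbers for more inhibition at the one concentration tested (going by the name of the read-out). Compound 1 `O=C1[C@@H](NS(=O)(=O)c2ccc(-c3ccccn3)s2)CCN1Cc1cc2[nH]cccc-2n1` gives 8%. Compound 3 `O=C1[C@@H](NS(=O)(=O)c2ccc(-c3ccccn3)s2)CCN1Cc1cc2c[nH]ccc-2n1` gives 11%. The change from compound 1 to compound 3 is a group of 9 heavy atoms (7 carbon, 2 nitrogen; one five-membered aromatic ring with 1 hetero atom, one six-membered aromatic ring with 1 hetero atom) in place of a group of 9 heavy atoms (7 carbon, 2 nitrogen; one five-membered aromatic ring with 1 hetero atom, one six-membered aromatic ring with 1 hetero atom), on a saturated chain carbon bound to an amide-type nitrogen in a ring, and it produced a step of a number 3 percentage points higher from compound 1 to compound 3 (within the scatter). Compound 2 `Cc1c(S(=O)(=O)N[C@H]2CCN(Cc3cc4[nH]cccc-4n3)C2=O)sc2ccc(Cl)cc12` gives 40%; the difference between the core of compound 1 and the core of compound 2 is not broken down here. Compound 4 `Cc1c(S(=O)(=O)N[C@H]2CCN(Cc3cc4c[nH]ccc-4n3)C2=O)sc2ccc(Cl)cc12` stands to compound 2 as compound 3 stands to compound 1: the change is a group of 9 heavy atoms (7 carbon, 2 nitrogen; one five-membered aromatic ring with 1 hetero atom, one six-membered aromatic ring with 1 hetero atom) in place of a group of 9 heavy atoms (7 carbon, 2 nitrogen; one five-membered aromatic ring with 1 hetero atom, one six-membered aromatic ring with 1 hetero atom), on a saturated chain carbon bound to an amide-type nitrogen in a ring, at a place worded the same, so it is the same change, occurring twice among these compounds. For compound 4 the expected step is a number 2 percentage points higher from compound 2 to compound 4 (within the scatter), set beside the earlier one, resting on the step of a number 3 percentage points higher from compound 1 to compound 3 (within the scatter) that this change gave. Compound 4 is therefore estimated at 42%, with an expected range from 28% to 56%.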

Compound 4, a percentage reported as inhibition, at one concentration (the size of the read-out at that concentration, not a potency): 37%
Compound 4: the middle estimate sits 5 percentage points above what was measured, within the range that was stated.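

In this assay the same change read on the second core gives a number 3 percentage points lower from compound 2 to compound 4 (within the scatter) and agrees with the earlier reading on the core of compound 1: the same change on two cores in this assay, a number 3 percentage points higher (within the scatter) from compound 1 to compound 3 and a number 3 percentage points lower (within the scatter) from compound 2 to compound 4, 6 percentage points apart, within the scatter of two such steps. On these two cores, then, exchanging one group for the other moves the read-out by no more than the scatter, whichever core carries it. Going by these compounds alone, this is only two small steps at a single concentration, so it shows neither that a real effect carries over between cores nor that the change would be as quiet on any other core.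

Open, on these data alone, is how the read-out responds when a different group stands at this place, such as a plain phenyl ring or a longer chain ending in an amine. Also open, as far as these compounds go, is whether these two groups stay level on a core with another sulfonyl substituent.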